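Swapping the aryl amide in a spiro-piperidine series

A few compounds are considered here, and "the series" means these few. Any claim that something is new, unique, unknown or untested is made for them only; others in the source may bear on it.

Measured compounds:
- Compound 1 `O=C1COc2ccc(S(=O)(=O)N3CCC4(CC3)C3C(=O)N(c5ccccc5)C(=O)C3CN4C(=O)c3cc(C(F)(F)F)cc(C(F)(F)F)c3)cc2N1`: in an assay on CHO cells for binding affinity to Substance-P receptor (Homo sapiens) (on this read-out higher numbers stand for weaker inhibition and lower numbers for stronger inhibition), compound 1 gives 30.9 nM
- Compound 2 `CS(=O)(=O)N1CCC2(CC1)C1C(=O)N(Cc3cc(C(F)(F)F)cc(C(F)(F)F)c3)C(=O)C1CN2C(=O)c1ccc2ccccc2c1`: in this assay compound 2 gives 263 nM
- Compound 3 `O=C1C2CN(C(=O)c3sc4ccccc4c3Cl)C3(CCNCC3)C2C(=O)N1Cc1cc(C(F)(F)F)cc(C(F)(F)F)c1`: in this assay compound 3 gives 501 nM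

Compound 3 and compound 2 give numbers that differ by less than the usual scatter of this assay, so nothing separates them. Compound 1, which carries a different sulfonyl group on the piperidine nitrogen and a different group on the imide nitrogen, gives a clearly lower number than compound 3, a gap beyond the scatter.

Compound 4 `COc1ccc(C(=O)N2CC3C(=O)N(Cc4cc(C(F)(F)F)cc(C(F)(F)F)c4)C(=O)C3C23CCNCC3)cc1OC` has not yet been measured. It differs from compound 3 in one place: 3,4-dimethoxyphenyl in place of 3-chloro-1-benzothiophen-2-yl on a carbonyl carbon. The rest of the shared core, including the free piperidine nitrogen and the bis(trifluoromethyl)benzyl group on the imide, is kept.

For the measured compounds named here, no measured pair in this set isolates this particular change, so there is no direct guide to its size. The expectation is a step of a 1.4-fold higher number from compound 3 to compound 4 (0.15 log units; within the scatter) that stays within or close to the scatter. For compound 4 the estimated value in this assay is 700 nM, with a range from 200 nM to 2500 nM.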

Compound 4, inhibition constant: 4270 nM
Compound 4: middle estimate off by 6.1-fold (0.79 log units), on the low side; the measured number lies above the stated range.
By their numbers in this assay, from the lowest: compound 1; then compounds 2 and 3 (each within the scatter of the next); then compound 4.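

In this assay the change from 3-chloro-1-benzothiophen-2-yl to 3,4-dimethoxyphenyl on a carbonyl carbon, with the rest of the molecule kept, gives an 8.5-fold higher number from compound 3 to compound 4 (0.93 log units; beyond the scatter) and so shows that the number responds clearly to the aromatic group at this position. The earlier compounds shown here could not show this, as they differ from one another in more than one place. Nothing available here explains why the number rises at this position.

From the compounds shown here alone, the group that leaves has two aromatic rings, sulfur and chlorine, while the group that enters has one aromatic ring and two methoxy groups, so it remains open which of these differences matters. A plain phenyl or a 3-chlorophenyl group on the same carbonyl carbon would help separate them, and the compounds shown do not say whether the step would hold with a sulfonyl group on the piperidine nitrogen.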